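A few compounds are considered here, and "the series" means these few. Any claim that something is new, unique, unknown or untested is made for them only; others in the source may bear on it.

Compound 1 `Nc1cc(-c2ccc(Cl)cc2)nn1-c1cccc(Cl)c1`: in a functional assay on Jurkat cells (Homo sapiens) for inhibition, read by MTT assay, with a stated time of 72 h (a lower number here means a stronger inhibitor of growth, a higher number a weaker inhibitor of growth), compound 1 reaches only the assay limit of > 100000 nM.
Compound 2 `Cc1ccc(-c2cc(/N=C/N(C)C)n(-c3cccc(Cl)c3)n2)cc1`: in this assay compound 2 likewise reaches only the assay limit of > 100000 nM.

Compound 2 therefore stands at the limit rather than at a number, and the same holds for every value shown (the limit of > 100000 nM in this assay, at which 2 of the 2 values shown sit). Compound 3 `CN(C)/C=N/c1cc(-c2ccc(Cl)cc2)nn1-c1cccc(Cl)c1` differs from compound 2 by chloro in place of methyl on an aromatic carbon. For the measured compounds named here, no measured step is available for this change. Since compound 2 sits at the limit (the limit of > 100000 nM in this assay, at which 2 of the 2 values shown sit), no shift beyond the scatter is expected, and the expected step is a step that the limit leaves unreadable from compound 2 to compound 3. Compound 3 is estimated at 150000 nM, within 50000 nM to 500000 nM, most probably again as a limit.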

Compound 3, concentration for 50% growth inhibition: 74500 nM
Beside the measured number, compound 3's estimate is 2.0-fold (0.30 log units) above it; the measured number falls inside the stated range.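

Compound 3 is the only compound shown in this assay that gives a number rather than a limit, so the change from 4-methylphenyl to 4-chlorophenyl now has a value on one side. This change gives an at least 1.3-fold lower number from compound 2 to compound 3 (0.12 log units; that floor lies within the scatter), and the group of 5 heavy atoms in place of one nitrogen atom gives an at least 1.3-fold lower number from compound 1 to compound 3 (0.12 log units; that floor lies within the scatter). Both steps are floors only, because the values they start from are limits: the limit of > 100000 nM in this assay, at which 2 of the 3 values shown sit.

Going by these compounds, how a fluoro or methoxy group would read at this position remains open, as does a longer chain in place of the group of 5 heavy atoms.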